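Ring size on the benzimidazole-type nitrogen and antagonist potency

The source may report more compounds than this note shows. Statements on the series, on what has been measured and on what is new or still open speak of the compounds shown alone.

Three analogues sharing one core have been measured in an assay on HEK-293T cells for antagonist activity at vitamin D3 receptor (Homo sapiens), read by a luciferase reporter, with a stated time of 24 h; a higher number here means a weaker inhibitor, a lower number a stronger inhibitor. Compound 1 `CC(C)c1onc(-c2c(Cl)cccc2Cl)c1COc1ccc(-c2nc3ccc(C(=O)O)cc3n2CC(C)(C)C)cc1` gives 861 nM, compound 2 `CC(C)c1onc(-c2c(Cl)cccc2Cl)c1COc1ccc(-c2nc3ccc(C(=O)O)cc3n2CC2CCCCC2)cc1` gives 346 nM, and compound 3 `CC(C)c1onc(-c2c(Cl)cccc2Cl)c1COc1ccc(-c2nc3ccc(C(=O)O)cc3n2C2CCC2)cc1` gives 1100 nM. Compound 3 therefore carries the highest of the three numbers; its nearest neighbour is compound 1, with a difference that stays within the usual scatter, while the gap to compound 2 is the largest, a 3.2-fold higher number from compound 2 to compound 3 (0.50 log units; beyond the scatter). The step of a 1.3-fold higher number from compound 1 to compound 3 (0.11 log units; within the scatter) is too small to count as a change, whereas a 2.5-fold lower number from compound 1 to compound 2 (0.40 log units; beyond the scatter) shows a modest shift toward a lower number.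

Compound 4 `CC(C)c1onc(-c2c(Cl)cccc2Cl)c1COc1ccc(-c2nc3ccc(C(=O)O)cc3n2C2CCCC2)cc1` is not yet measured. It differs from compound 3 in one place: cyclopentyl in place of cyclobutyl on an aromatic nitrogen. Going by the values given here, the only measured steps that touch this position are those just described. Because a 3.2-fold higher number from compound 2 to compound 3 (0.50 log units; beyond the scatter) links a larger ring-bearing substituent on this nitrogen to a lower number, and because a 1.3-fold higher number from compound 1 to compound 3 (0.11 log units; within the scatter) shows a saturated substituent of comparable size giving a near-identical result, the move to cyclopentyl is expected to lower the number only slightly, likely within or just beyond the scatter. For compound 4 in this assay the estimate is 700 nM, with a range from 350 nM to 1400 nM, corresponding to an expected step of a 1.6-fold lower number from compound 3 to compound 4 (0.20 log units; within the scatter).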

Compound 4, half-maximal inhibitory concentration: 929 nM
Beside the measured number, compound 4's estimate is 1.3-fold (0.12 log units) below it, and the stated range covers the measured number.
By their numbers in this assay, from the lowest: compound 2; then compounds 1, 4 and 3 (each within the scatter of the next).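

In this assay, the direct swap of ring size on the aromatic nitrogen gives a 1.2-fold lower number from compound 3 to compound 4 (0.07 log units; within the scatter), so cyclopentyl and cyclobutyl cannot be told apart at this position. Cyclopentyl also cannot be told apart from neopentyl (a 1.1-fold higher number from compound 1 to compound 4 (0.03 log units; within the scatter)), whereas cyclohexylmethyl remains distinct from cyclopentyl (a 2.7-fold higher number from compound 2 to compound 4 (0.43 log units; beyond the scatter)), leaving compound 2 as the only one of the four whose steps to all the others lie beyond the scatter and compounds 1, 3 and 4 as a group within the scatter of one another. No measurement on these compounds offers an explanation for this pattern.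

The compounds shown leave open whether the lower number of compound 2 goes with the cyclohexyl ring itself or with the methylene that joins it to the aromatic nitrogen, since the two differ together in every comparison here, and cyclohexyl bound directly to that nitrogen or cyclopentylmethyl would separate them. They also leave open how a ring carrying a heteroatom, such as tetrahydropyranyl or piperidinyl, would compare at this position.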